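Pyridyl swap on the thiophene sulfonamide series

This account rests on a few compounds, and the source may have more. Where it says the series, first, only, none or still open, it means among the compounds named here.

Compound 2 `O=C1[C@@H](NS(=O)(=O)c2ccc(-c3ccncc3)s2)CCN1Cc1cc2c[nH]ccc-2n1` gives 21% in an assay on isolated protein for inhibition of coagulation factor X (Oryctolagus cuniculus), tested at 1 uM; a higher number here means more inhibition at the concentration tested (going by the name of the read-out), a lower number less inhibition. Compound 1 `O=C1[C@@H](NS(=O)(=O)c2ccc(-c3ccccn3)s2)CCN1Cc1cc2c[nH]ccc-2n1` gives 11% in this assay; the change pyridin-2-yl in place of pyridin-4-yl on an aromatic carbon made the step of a number 10 percentage points lower from compound 2 to compound 1 (within the scatter). Compound 3 `O=C1[C@@H](NS(=O)(=O)c2ccc(-c3ccncc3)s2)CCN1CCNc1ccncc1` gives 41% in this assay, the highest of the three numbers; its core differs from that of compound 2 by a group of 8 heavy atoms (6 carbon, 2 nitrogen; one six-membered aromatic ring with 1 hetero atom) in place of a group of 9 heavy atoms (7 carbon, 2 nitrogen; one five-membered aromatic ring with 1 hetero atom, one six-membered aromatic ring with 1 hetero atom), on a saturated chain carbon bound to an amide-type nitrogen in a ring, and the step is a number 20 percentage points higher from compound 2 to compound 3 (beyond the scatter). Compound 4 `O=C1[C@@H](NS(=O)(=O)c2ccc(-c3ccccn3)s2)CCN1CCNc1ccncc1` carries the change pyridin-2-yl in place of pyridin-4-yl on an aromatic carbon relative to compound 3, the same change as from compound 2 to compound 1, at the same place. Among the measured compounds shown here, the step of a number 9 percentage points lower from compound 3 to compound 4 (within the scatter) is expected beside a number 10 percentage points lower from compound 2 to compound 1 (within the scatter), resting on compound 2 and compound 1, whose pair is the only example of this change measured. Compound 4 is therefore estimated at 32% in this assay, between 16% and 48%.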

Compound 4, a percentage reported as inhibition, at one concentration (the size of the read-out at that concentration, not a potency): 18%
The estimate for compound 4 lay 14 percentage points above the measured number; measured number inside the range.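

In this assay, pyridin-2-yl in place of pyridin-4-yl gives a number 23 percentage points lower from compound 3 to compound 4 (beyond the scatter), and this step does not differ beyond the scatter from the earlier example of the change: the same change on two cores in this assay, a number 10 percentage points lower (within the scatter) from compound 2 to compound 1 and a number 23 percentage points lower (beyond the scatter) from compound 3 to compound 4, 13 percentage points apart, within the scatter of two such steps

The exchange of the larger group on the saturated chain carbon gives a number 7 percentage points higher from compound 1 to compound 4 (within the scatter), and the two examples of that exchange also stay together: the same change on two cores in this assay, a number 20 percentage points higher (beyond the scatter) from compound 2 to compound 3 and a number 7 percentage points higher (within the scatter) from compound 1 to compound 4, 13 percentage points apart, within the scatter of two such steps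

This supports carrying each change between these two cores, but it does not show that the steps are equal in size, and two cores fix no general rule.

Still open, going by these compounds, is whether the same holds with pyridin-3-yl or phenyl on the aromatic carbon. A longer chain in the exchanged group on the saturated chain carbon is also untested by the compounds shown here.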